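Diazoketone Esters: Isopropyl to Ethyl

This account rests on a few compounds, and the source may have more. Where it says the series, first, only, none or still open, it means among the compounds named here.

Measured so far:
compound 1, `CC(C)[C@H](N)C(=O)N[C@@H](CCC(=O)C=[N+]=[N-])C(=O)OCc1c[nH]c2ccccc12`: 0%
compound 2, `CCC(OC(=O)N[C@@H](CCC(=O)C=[N+]=[N-])C(=O)OC)OC(=O)C(C)(C)C`: 0%
compound 3, `COC(=O)[C@H](CCC(=O)C=[N+]=[N-])NC(=O)OC(OC(=O)C(C)(C)C)C(C)C`: 0%

In an ADME assay on a cell-free system (plasma, Mus musculus) for metabolic stability, read by LC-MS, with a stated time of 60 min, tested at 10 uM (a lower number here means that less of the compound is left, a higher number that more of the compound is left), compound 1 gives 0%, compound 2 gives 0% and compound 3 gives 0%. The three values sit level with one another at the digits printed.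

Compound 3 and compound 2 differ in one place, (hydrogen in place of methyl on a saturated chain carbon bound to two saturated chain carbons), and the step of no change at the digits printed from compound 3 to compound 2 (within the scatter). Compound 1 and compound 3 are built on different cores, and the difference between the two cores is not broken down here.

Compound 4, `CC[C@H](N)C(=O)N[C@@H](CCC(=O)C=[N+]=[N-])C(=O)OCc1c[nH]c2ccccc12`, has not yet been measured. It is related to compound 1 by the same change, (hydrogen in place of methyl on a saturated chain carbon bound to two saturated chain carbons), made on the core of compound 1 instead of the core of compound 3. For compound 1 to compound 4 in this assay the expected step is no change at the digits printed from compound 1 to compound 4 (within the scatter), which rests on compound 3 and compound 2, because no change at the digits printed from compound 3 to compound 2 (within the scatter). Compound 4 is therefore expected to give 0%, with an expected range from 0% to 10%.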

Compound 4, percent of the compound remaining: 0%
The estimate for compound 4 equals the measured number at the digits printed; measured number inside the range.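

On the core of compound 1, putting ethyl in place of isopropyl gives no change at the digits printed from compound 1 to compound 4 (within the scatter), and set beside the same change on the other core, the result is the same: the same change on two cores in this assay, no change at the digits printed (within the scatter) from compound 3 to compound 2 and no change at the digits printed (within the scatter) from compound 1 to compound 4, 0 percentage points apart, within the scatter of two such steps All four compounds read alike, with compound 4 at 0%, a reading at which none of the compound is left. Within the data shown here, the agreement between the two cores therefore shows only that this change did not raise the value on either core, and it does not show how the change would carry over to a compound of which some remains at the end of the incubation.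

The compounds shown leave open whether a longer chain such as butyl, or a phenyl group, in place of isopropyl would leave more of the compound in this assay. They also leave open how the change from isopropyl to ethyl would read on a core with a carboxylic acid in place of the diazoketone.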